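Pentyl on the saturated chain of compound 1

The compounds below may be only part of what the source reports. "The series", "measured", "known", "first", "only" and "open" are said of these compounds alone.

In a functional assay on HCT-116 cells (Homo sapiens) for antiproliferative activity, read by MTT assay, with a stated time of 48 h (on this read-out lower numbers stand for stronger inhibition and higher numbers for weaker inhibition), compound 1 (`CCC(CCO)n1cnc2c(Cl)nc(F)nc21`) gives 18900 nM, the higher of the two numbers in the series. Compound 3 (`CCCCCC(CCO)n1cnc2c(Cl)nc(Cl)nc21`) gives 6170 nM, a gap from compound 1 that lies beyond the scatter. Compound 2 (`CCC(CCO)n1cnc2c(Cl)ncnc21`) reports only a limit, > 50000 nM.

The step to compound 4 (`CCCCCCCC(CCO)n1cnc2c(Cl)nc(F)nc21`) is pentyl in place of hydrogen on a saturated chain carbon, three bonds along the chain from an aromatic nitrogen. Within the data shown here, the one measured step is an at least 2.6-fold higher number from compound 1 to compound 2 (0.42 log units; beyond the scatter), with hydrogen in place of fluoro on an aromatic carbon. It is at least modest, but it concerns a different place and gives no direct size for the chain change. Among the measured compounds shown here, no measured step isolates that change, so the expectation leans on the lower number of compound 3 at 6170 nM, and only loosely. A modest move towards stronger inhibition in this assay is expected, with wide uncertainty.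

The expected change is a 4.2-fold lower number from compound 1 to compound 4 (0.62 log units; beyond the scatter). For compound 4, the estimated value is 4500 nM, with an expected range of 1300 nM to 15000 nM.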

Compound 4, half-maximal inhibitory concentration: 17600 nM
Compound 4: middle estimate off by 3.9-fold (0.59 log units), on the low side, and the stated range ends below it.
By their numbers in this assay, from the lowest: compound 3; then compounds 4 and 1 (each within the scatter of the next). At a limit, above all of these: compound 2.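

Pentyl in place of hydrogen on a saturated chain carbon, three bonds along the chain from an aromatic nitrogen, gives in this assay a 1.1-fold lower number from compound 1 to compound 4 (0.03 log units; within the scatter), so with fluoro kept on the core, compound 1 and compound 4 cannot be told apart. Compound 3 differs from compound 1 in more than one place, so compound 3 at 6170 nM gives no size for the chain change alone. Nothing shown gives a cause for this flat step.

Going by these compounds, whether an amine or a carboxylic acid at the end of the added chain would shift the number at this position remains open. The same holds for a longer chain, and for the pairing of pentyl with chloro in place of fluoro on the core of compound 4.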